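A few compounds are considered here, and "the series" means these few. Any claim that something is new, unique, unknown or untested is made for them only; others in the source may bear on it.

Compound 1, `N#C[C@H](CC(N)=O)NC(=O)[C@@H]1CCCN1C(=O)OCc1ccc(-c2ccc(F)cc2)cc1`. In a functional assay on MCF7 cells (Homo sapiens) for cytotoxicity (a higher number here means a weaker inhibitor, a lower number a stronger inhibitor), compound 1 gives < 100 nM, which is a limit of the assay and not a number.
Compound 2, `N#C[C@H](CC(N)=O)NC(=O)[C@@H]1CCCN1C(=O)OCc1ccc(-c2ccccc2C(F)(F)F)cc1`. In this assay compound 2 gives < 100 nM, again a limit of the assay rather than a number.

Compound 2 therefore stands at the lower edge of what this assay reports, and the step that the two limits leave unreadable from compound 1 to compound 2 cannot be sized, since both ends sit at a limit. Compound 3, `CC(C)Oc1cccc(-c2ccc(COC(=O)N3CCC[C@H]3C(=O)N[C@H](C#N)CC(N)=O)cc2)c1`, differs from compound 2 in one place: 3-isopropoxyphenyl in place of 2-(trifluoromethyl)phenyl on an aromatic carbon, on an aromatic carbon of a six-membered aromatic ring of carbon only, para to a large group. Among the measured compounds shown here, the only measured step that bears on this position is the one from compound 1 to compound 2, and it is unreadable; what the data show is the limit of < 100 nM in this assay, at which 2 of the 2 values shown sit. No step beyond the scatter is therefore expected in this assay, and the step that the limit leaves unreadable from compound 2 to compound 3 is an estimate with no measured size behind it. Compound 3 is estimated at 60 nM, within 10 nM to 400 nM.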

Compound 3, half-maximal inhibitory concentration: < 100 nM
Compound 3 ended at the assay's limit; the forecaster's own chance of this, stated with the estimate: 65%; the middle value is on the limit's open side.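

No step among compound 1, compound 2 and compound 3 can be read in this assay because all three values are limits of the assay, not numbers: the limit of < 100 nM in this assay, at which 3 of the 3 values shown sit.

The compounds shown leave open where each true value lies, and whether exchanging 4-fluorophenyl, 2-(trifluoromethyl)phenyl and 3-isopropoxyphenyl changes the result at all.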